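The source may hold more compounds than are shown below. What is called first, only, known or untested is meant among the compounds shown, and "the series" means these compounds.

Compound 1 `Cc1cccc(S(=O)(=O)NCc2ccc(CNC(=O)c3ccc(CNc4ncccn4)cc3)cc2)c1` has the lower of the two numbers that were actually read. In an assay on MDA-MB-231 cells for binding affinity to C-X-C chemokine receptor type 4 (Homo sapiens), read by microscopy, with stated times of 10 min and 30 min (on this read-out higher numbers stand for an effect only at larger amounts of compound and lower numbers for an effect already at smaller amounts), compound 1 gives 100 nM. Compound 2 `O=C(NCc1ccc(CNS(=O)(=O)c2cccc3ccccc23)cc1)c1ccc(CNc2ncccn2)cc1` gives 1000 nM in this assay. For compound 3 `O=C(NCc1ccc(CNS(=O)(=O)c2cccnc2)cc1)c1ccc(CNc2ncccn2)cc1` the assay reports only a limit, > 1000 nM. The measured changes on the sulfonyl sulfur both raised the number: a 10-fold higher number from compound 1 to compound 2 (1.00 log units; beyond the scatter) and an at least 10-fold higher number from compound 1 to compound 3 (1.00 log units; beyond the scatter). Compound 4 `O=C(NCc1ccc(CNS(=O)(=O)c2ccccc2Cl)cc1)c1ccc(CNc2ncccn2)cc1` differs from compound 1 at the same place: 2-chlorophenyl in place of 3-methylphenyl on a sulfonyl sulfur. Since both known replacements of the 3-methylphenyl weakened binding, a rise of modest size is expected here too, though the 2-chlorophenyl is smaller than naphthalen-1-yl. For compound 4 the expected value is 300 nM, with a range from 100 nM to 1000 nM. That estimate means a 3.0-fold higher number from compound 1 to compound 4 (0.48 log units; beyond the scatter).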

Compound 4, effective concentration (reported as EC, without a stated level of effect): 1000 nM
Compound 4: middle estimate off by 3.3-fold (0.52 log units), on the low side; the measured number falls inside the stated range.
By their numbers in this assay, from the lowest: compound 1; then compounds 2 and 4 (each within the scatter of the next).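

The heavy-atom count and the single six-membered aromatic ring of carbon only stay the same on the sulfonyl sulfur, yet 2-chlorophenyl in place of 3-methylphenyl still gives a 10-fold higher number from compound 1 to compound 4 (1.00 log units; beyond the scatter). Thus, among the compounds shown, a rise needs neither a larger group nor a ring nitrogen, and against the much larger naphthalen-1-yl, 2-chlorophenyl gives no change at the digits printed from compound 2 to compound 4 (within the scatter). With 2-chlorophenyl in place of pyridin-3-yl, the data give a number no higher from compound 3 to compound 4 (the limit leaves the size open). The size of that step cannot be read, because the starting value is only a limit: the limit of > 1000 nM in this assay, at which 1 of the 4 values shown sits.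

On these data alone, what a plain phenyl or an aminophenyl on the sulfonyl sulfur would give stays open, and so does how much of the lower number of compound 1 rests on its methyl.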